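The source may hold more compounds than are shown below. What is called first, only, known or untested is meant among the compounds shown, and "the series" means these compounds.

In a functional assay on U-87MG ATCC cells (Homo sapiens) for antiproliferative activity, read by MTT assay, with a stated time of 48 h (on this read-out lower numbers stand for stronger inhibition and higher numbers for weaker inhibition), three compounds built on one shared core have been measured. Compound 1 `O=C(/C=C\Nc1ccc(C(F)(F)F)cc1)c1cn(-c2ccccc2)nc1-c1ccc(F)cc1` carries a trifluoromethyl group on an aromatic carbon, and in this assay compound 1 reaches only the limit of the measurement, > 50000 nM. Compound 2 `O=C(/C=C\Nc1ccc(O)cc1)c1cn(-c2ccccc2)nc1-c1ccc(F)cc1` carries a hydroxy group in place of that trifluoromethyl, and in this assay compound 2 gives 4700 nM. Compound 3 `COc1ccc(N/C=C\C(=O)c2cn(-c3ccccc3)nc2-c2ccc(F)cc2)cc1` carries a methoxy group in its place, and in this assay compound 3 gives 2500 nM. Both an at least 10-fold lower number from compound 1 to compound 2 (1.02 log units; beyond the scatter) and an at least 20-fold lower number from compound 1 to compound 3 (1.30 log units; beyond the scatter) are large steps, whereas a 1.9-fold lower number from compound 2 to compound 3 (0.27 log units; within the scatter) stays within the scatter. Compound 3 thus holds the lower of the two numbers shown, but its gap to compound 2 is within the scatter, and compound 1 is known only as a limit.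

Compound 4 `COc1ccc(N/C=C\C(=O)c2cn(-c3ccccc3)nc2-c2ccc(Cl)cc2)cc1` differs from compound 3 in one place: chloro in place of fluoro on an aromatic carbon. Among the measured compounds shown here, none of the measured steps touches this ring; all three concern the group on the other aromatic ring. So no measured step bears directly on this change, and no step beyond the scatter is expected in this assay. The change from compound 3 to compound 4 is estimated at no change at the digits printed from compound 3 to compound 4 (within the scatter). Compound 4 is therefore expected to give about 2500 nM in this assay, within a range from 1000 nM to 6500 nM.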

Compound 4, half-maximal inhibitory concentration: 6890 nM
Compound 4: middle estimate off by 2.8-fold (0.44 log units), on the low side; measured number above the stated range.
By their numbers in this assay, from the lowest: compounds 3, 2 and 4 (each within the scatter of the next, the first and the last beyond it). At a limit, above all of these: compound 1.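

Among the compounds shown here, until now every measured step concerned the group on the other aromatic ring, so this is the first sign that the ring carrying the halogen also counts in this assay: going from 4-fluorophenyl to 4-chlorophenyl gives a 2.8-fold higher number from compound 3 to compound 4 (0.44 log units; beyond the scatter), a modest step towards weaker inhibition. The exchange is small on paper, one heavy atom for one heavy atom, with no ring, hydrogen-bond donor, hydrogen-bond acceptor or net charge entering or leaving, yet the number still moves beyond the scatter. Nothing given here bears on what lies behind this step, so the result records a change without explaining it.

The compounds shown leave open whether a bromo group, a methyl group, a nitrile or an amine at this place would continue the trend from fluoro to chloro or break it, since two halogens alone cannot define a trend. For the compounds shown here, it also remains open whether the same exchange would give a similar step with hydroxy or trifluoromethyl on the other ring, as it has been seen only with methoxy there.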